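The source may hold more compounds than are shown below. What is called first, only, known or untested is meant among the compounds shown, and "the series" means these compounds.

Of the compounds shown here, three have been measured in a functional assay on HepG2 cells (Homo sapiens) for antiproliferative activity, read by MTT assay, with a stated time of 48 h; on this read-out higher numbers stand for weaker inhibition and lower numbers for stronger inhibition.

Compound 1, `CCn1cc(-c2ccc(F)cc2)c(=O)c2cc(F)c(N3CCNCC3)cc21`, gives 56200 nM in this assay.
Compound 2, `CCn1cc(-c2ccc(Cl)cc2)c(=O)c2cc(F)c(N3CCNCC3)cc21`, gives 24000 nM in this assay.
Compound 3, `O=c1c(-c2cccc(F)c2)cn(C2CC2)c2cc(N3CCNCC3)c(F)cc12`, gives 7380 nM in this assay.

Compound 2 differs from compound 1 in a single place: chloro in place of fluoro on an aromatic carbon. That change brought a 2.3-fold lower number from compound 1 to compound 2 (0.37 log units; beyond the scatter). Compound 3 stands lowest of the three numbers, with compound 2 nearest and compound 1 furthest. The difference between the core of compound 3 and the core of compound 1 is not broken down here.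

Compound 4, `O=c1c(-c2cccc(Cl)c2)cn(C2CC2)c2cc(N3CCNCC3)c(F)cc12`, has not yet been measured. It differs from compound 3 in a single place: chloro in place of fluoro on an aromatic carbon. Within the data shown here, this is the same kind of change as the one from compound 1 to compound 2, but not the same change: in the earlier pair the chlorine enters para to a large group, here it enters meta to a large group, and the surrounding core is a different one. Among the measured compounds shown here, with only one earlier example, on another core and at another place, the expectation can lean on it only loosely, and a somewhat smaller step seems prudent. The step from compound 3 to compound 4 is estimated at a 1.8-fold lower number from compound 3 to compound 4 (0.27 log units; within the scatter) because the earlier pair showed a 2.3-fold lower number from compound 1 to compound 2 (0.37 log units; beyond the scatter). Compound 4 is therefore expected to give about 4000 nM in this assay, most likely falling between 2000 nM and 9000 nM.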

Compound 4, half-maximal inhibitory concentration: 860 nM
Beside the measured number, compound 4's estimate is 4.7-fold (0.67 log units) above it, and the stated range ends above it.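

In this assay, putting chloro in place of fluoro on the aromatic ring, here the change from 3-fluorophenyl to 3-chlorophenyl, brought an 8.6-fold lower number from compound 3 to compound 4 (0.93 log units; beyond the scatter) and so went the same way as the earlier pair. Set side by side, the two steps agree in direction but not in size: the same change on two cores in this assay, a 2.3-fold lower number (0.37 log units; beyond the scatter) from compound 1 to compound 2 and an 8.6-fold lower number (0.93 log units; beyond the scatter) from compound 3 to compound 4, 3.7-fold (0.56 log units) apart, beyond the scatter of two such steps

This shows that, in these two pairs, the swap lowered the number both times, but that the size of the step seen on one core cannot simply be carried over to another. It does not show what sets that size, since the two pairs differ both in their core and in where the halogen sits on the aromatic ring, and two pairs cannot separate these or give a reason for the gap.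

The compounds shown leave open whether chloro at the place it holds in compound 4 would give a similarly large step on the core of compound 1, which would help to separate the effect of the core from that of the position. They also leave open how a bromo, methyl or methoxy group at that same place would compare with the chloro of compound 4.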